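This account rests on a few compounds, and the source may have more. Where it says the series, first, only, none or still open, it means among the compounds named here.

Within the data shown here, compound 2 `O=C(/C=C\Nc1ccc(S(=O)(=O)Nc2cnc3ccccc3n2)cc1)c1cc2ccccc2oc1=O` gives 86900 nM in a functional assay on T47D cells (Homo sapiens) for cytotoxicity, read by sulforhodamine B assay, with a stated time of 48 h (a higher number here means a weaker inhibitor, a lower number a stronger inhibitor), and stands lowest of the two numbers so far; its neighbour, compound 1 `Cc1nnc(NS(=O)(=O)c2ccc(N/C=C\C(=O)c3cc4ccccc4oc3=O)cc2)s1`, gives 94000 nM in this assay, and the step of a 1.1-fold lower number from compound 1 to compound 2 (0.03 log units; within the scatter) is within the scatter. Compound 3 `Nc1ccc(S(=O)(=O)c2ccc(N/C=C\C(=O)c3cc4ccccc4oc3=O)cc2)cc1` differs from compound 2 by 4-aminophenyl in place of (quinoxalin-2-yl)amino on a sulfonyl sulfur. Among the measured compounds shown here, no measured step touches the sulfonyl sulfur; the single step known concerns the sulfonamide nitrogen only and was within the scatter, so nothing anchors a direction here. Compound 3 is therefore expected near compound 2, at 90000 nM in this assay, with a range of 30000 nM to 270000 nM, a step of a 1.0-fold higher number from compound 2 to compound 3 (0.02 log units; within the scatter) in expectation.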

Compound 3, half-maximal inhibitory concentration: 91900 nM
Estimate against measurement, compound 3: 1.0-fold (0.01 log units) below, and the stated range covers the measured number.
By their numbers in this assay, from the lowest: compounds 2, 3 and 1 (each within the scatter of the next).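

In this assay, 4-aminophenyl on the sulfonyl sulfur reads level with (quinoxalin-2-yl)amino (a 1.1-fold higher number from compound 2 to compound 3 (0.02 log units; within the scatter)) and with (5-methyl-1,3,4-thiadiazol-2-yl)amino (a 1.0-fold lower number from compound 1 to compound 3 (0.01 log units; within the scatter)). An aromatic group without the sulfonamide nitrogen therefore gives a number within the scatter of both nitrogen-linked groups, so that nitrogen shows no measurable contribution among these compounds. No supporting evidence bears on this result.

Going by these compounds, whether any group at this place can move the number remains open. A plain amine on the sulfonyl sulfur, or a carboxylic acid in place of the amine of 4-aminophenyl, would test this.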